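Swapping the sulfonamide arm of compound 2 for a thiophene

A few compounds are considered here, and "the series" means these few. Any claim that something is new, unique, unknown or untested is made for them only; others in the source may bear on it.

Three compounds have numbers in a functional assay on CHO-K1 cells for antagonist activity at Urotensin-2 receptor (Rattus norvegicus), read by FLIPR and calcium flux, with a stated time of 1 h; a higher number here means a weaker inhibitor, a lower number a stronger inhibitor. Compound 1, `COc1cc(Br)c(S(=O)(=O)Nc2ccc(C(F)(F)F)c(O[C@@H]3CCN(C)C3)c2)cc1OC`, gives 34 nM. Compound 2, `CCN1CCN(c2cccc3c2CN([C@H](CCCNS(=O)(=O)c2c[nH]cn2)c2ccc(OC)c(OC)c2)C3=O)CC1`, gives 23 nM, which is the second highest of the three numbers. Its nearest neighbour on the scale is compound 1, and that gap lies within the scatter of the measurement. Compound 3, `COc1ccc([C@@H](CCCN(C)S(=O)(=O)c2cccs2)N2Cc3c(cccc3N3CCN(C4CC4)CC3)C2=O)cc1OC`, gives 13 nM, and its gap to compound 2 also lies within the scatter, so the three compounds cannot be put in any firm order on these numbers alone.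

Compound 4, `CCN1CCN(c2cccc3c2CN([C@H](CCCN(C)S(=O)(=O)c2cccs2)c2ccc(OC)c(OC)c2)C3=O)CC1`, has not yet been measured. It differs from compound 2 in one place: methyl((thiophen-2-yl)sulfonyl)amino in place of ((1H-imidazol-4-yl)sulfonyl)amino on a saturated chain carbon, four bonds along the chain from an amide-type nitrogen in a ring and an aromatic carbon. For the measured compounds named here, no pair of measured compounds differs in exactly this way, so no measured step can be read off. Compound 3, however, already carries the methyl((thiophen-2-yl)sulfonyl)amino group on its own chain and gives 13 nM, a number within the scatter of compound 2.

On this basis the account expects no step beyond the scatter, and the estimated step is a 1.4-fold lower number from compound 2 to compound 4 (0.16 log units; within the scatter). For compound 4 the expected value in this assay is 16 nM, with an estimated range from 6 nM to 45 nM.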

Compound 4, half-maximal inhibitory concentration: 7 nM
The estimate for compound 4 lay 2.3-fold (0.36 log units) above the measured number, within the range that was stated.
By their numbers in this assay, from the lowest: compounds 4, 3, 2 and 1 (each within the scatter of the next, the first and the last beyond it).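

At this place on the chain, methyl((thiophen-2-yl)sulfonyl)amino in place of ((1H-imidazol-4-yl)sulfonyl)amino gives a 3.3-fold lower number from compound 2 to compound 4 (0.52 log units; beyond the scatter) in this assay, the only step among these compounds that stands beyond the scatter, and it comes with a change from 2 hydrogen-bond donors in the leaving group to 0 in the entering one. With the entering group held constant, ethyl in place of cyclopropyl on an amine nitrogen in a ring gives a 1.9-fold lower number from compound 3 to compound 4 (0.27 log units; within the scatter), so that exchange cannot be told apart from the scatter. Nothing at hand accounts for the larger step.

The compounds shown leave open which part of the entering group carries that step, as no pair among them separates the methyl from the thiophene, and the step therefore cannot be assigned to either one alone. They also leave open how this position would read with a phenyl ring on the sulfonyl group, with a carboxylic acid in place of the sulfonamide, or with a longer chain.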